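From a fused bicyclic amine to a hydroxypiperidine

A few compounds are considered here, and "the series" means these few. Any claim that something is new, unique, unknown or untested is made for them only; others in the source may bear on it.

Compound 1 `O=S(=O)(c1ccccc1)c1nc2ccccc2nc1N1CCc2ccccc2C1` gives 5010 nM in a functional assay on PC-3 cells (Homo sapiens) for cytotoxicity, read by MTT assay, with a stated time of 72 h; on this read-out higher numbers stand for weaker inhibition and lower numbers for stronger inhibition. Compound 3 `O=S(=O)(c1ccc(F)cc1)c1nc2ccccc2nc1N1CCc2ccccc2C1` gives 9230 nM in this assay, and the step of a 1.8-fold higher number from compound 1 to compound 3 (0.27 log units; within the scatter) stays within the scatter. Compound 2 `COc1ccc(S(=O)(=O)c2nc3ccccc3nc2N2CCc3ccccc3C2)cc1` reaches only the limit > 50000 nM in this assay. Among the compounds with values here, it is the one value sitting at the limit of > 50000 nM in this assay, at which 1 of the 3 values shown sits. Compound 2 thus stands at the weak end of the three, since the step of an at least 9.9-fold higher number from compound 1 to compound 2 (0.99 log units; beyond the scatter) and the step of an at least 5.4-fold lower number from compound 2 to compound 3 (0.73 log units; beyond the scatter) both set it beyond the scatter from the other two. Compound 4 `COc1ccc(S(=O)(=O)c2nc3ccccc3nc2N2CCC(O)CC2)cc1` keeps the methoxy-bearing sulfonyl side of compound 2 and changes the amine: 4-hydroxypiperidin-1-yl in place of 1,2,3,4-tetrahydroisoquinolin-2-yl on an aromatic carbon. Within the data shown here, none of the measured steps touches this position; all three concern the aromatic ring on the sulfonyl group, so nothing measured shows what this exchange does in this assay. Starting from a limit, the value of compound 4 in this assay is expected to remain near or beyond that limit, an expected step that the limit leaves unreadable from compound 2 to compound 4. Compound 4 is therefore estimated at 70000 nM, between 15000 nM and 300000 nM.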

Compound 4, half-maximal inhibitory concentration: 9730 nM
Compound 4: the middle estimate sits 7.2-fold (0.86 log units) above what was measured, outside the stated range (below it).
By their numbers in this assay, from the lowest: compounds 1, 3 and 4 (each within the scatter of the next). At a limit, above all of these: compound 2.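

Within the data shown here, the amine position had not varied among the earlier compounds, and compound 4 shows that it matters in this assay: with the methoxy-bearing sulfonyl side held fixed, 4-hydroxypiperidin-1-yl in place of 1,2,3,4-tetrahydroisoquinolin-2-yl gives an at least 5.1-fold lower number from compound 2 to compound 4 (0.71 log units; beyond the scatter). This change brings the methoxy-bearing compound from a limit to a measured value, so a methoxy group on the sulfonyl ring does not by itself rule out a measurable value. The value of compound 2 is a limit, so the step reads only as a minimum: the limit of > 50000 nM in this assay, at which 1 of the 4 values shown sits.

The compounds shown leave open whether the hydroxyl group counts or only the loss of 1,2,3,4-tetrahydroisoquinolin-2-yl, a question that a plain piperidine or a morpholine would address. Also open, going by these compounds, is what 4-hydroxypiperidin-1-yl does with the sulfonyl rings of compound 1 and compound 3.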